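Shortening the sulfur-bound chain of compound 3

This account rests on a few compounds, and the source may have more. Where it says the series, first, only, none or still open, it means among the compounds named here.

Compound 1 `CCOc1nc(N)nc2c1ncn2/C=C1/CC1(CO)CO`: > 20000 nM
Compound 2 `CCCNc1nc(N)nc2c1ncn2/C=C1/CC1(CO)CO`: "not determined" (no result reported)
Compound 3 `CCCCCCSc1nc(N)nc2c1ncn2/C=C1/CC1(CO)CO`: > 20000 nM

All three compounds were examined in an ADME assay on MOLT-3 cells (Homo sapiens) for cytotoxicity, with a stated time of 7 days (a higher number here means that more compound is tolerated, a lower number that less compound is tolerated), and the two results available are limits rather than numbers. Compound 3 gives only a limit, > 20000 nM. Together with compound 1, it stands at the limit of > 20000 nM in this assay, at which 2 of the 3 values shown sit. Compound 2 gives no result that could be compared.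

The compound still to be measured is compound 4 `CCCCSc1nc(N)nc2c1ncn2/C=C1/CC1(CO)CO`. It differs from compound 3 as follows: hydrogen in place of ethyl on a saturated chain carbon, four bonds along the chain from a sulfur. In words, hydrogen stands in place of ethyl on a saturated chain carbon, four bonds along the chain from a sulfur.

Among the compounds with values here, only one measured step bears on this change, a step that the two limits leave unreadable from compound 1 to compound 3. It offers neither a size nor a direction for the new step. The expectation therefore rests mainly on compound 3, whose limit is > 20000 nM. No shift beyond the usual scatter can be argued from these data, and no direction is expected in this assay. The expected outcome is a number no higher from compound 3 to compound 4 (the limit leaves the size open). Another limit would be the most likely report. For compound 4 the estimate is 20000 nM, with an expected range of 10000 nM to 40000 nM.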

Compound 4, half-maximal cytotoxic concentration: > 20000 nM
Compound 4 was reported as a limit; the forecaster's own chance of this, stated with the estimate: 80%; the middle value lies on the limit itself.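

Compound 4, like compound 1 and compound 3, is reported in this assay only as a limit and not as a number, so no step among these three compounds can be read: the limit of > 20000 nM in this assay, at which 3 of the 4 values shown sit.

The compounds shown leave open whether butylsulfanyl and hexylsulfanyl differ at all in cytotoxicity, and at what concentration any of these compounds becomes cytotoxic.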